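A few compounds are considered here, and "the series" means these few. Any claim that something is new, unique, unknown or untested is made for them only; others in the source may bear on it.

Measured in a functional assay on HUVEC cells (Homo sapiens), read by scintillation counting and thymidine incorporation, with a stated time of 24 h; on this read-out lower numbers stand for stronger inhibition and higher numbers for weaker inhibition:
- Compound 1 `CCC(C)n1ncn(-c2ccc(N3CCN(c4ccc(OC[C@@H]5CO[C@@](CC)(c6ccc(Cl)cc6Cl)O5)cc4)CC3)cc2)c1=O`: 353 nM
- Compound 2 `CCC(C)n1ncn(-c2ccc(N3CCN(c4ccc(OC[C@@H]5CO[C@@](Cn6nc(C)nc6C)(c6ccc(Cl)cc6Cl)O5)cc4)CC3)cc2)c1=O`: 221 nM
- Compound 3 `CCC(C)n1ncn(-c2ccc(N3CCN(c4ccc(OC[C@@H]5CO[C@@](Cn6c(C)cnc6C)(c6ccc(Cl)cc6Cl)O5)cc4)CC3)cc2)c1=O`: 765 nM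

Compound 3 has the highest number of the three, making it the weakest inhibitor so far. Compound 4 `CCC(C)n1ncn(-c2ccc(N3CCN(c4ccc(OC[C@@H]5CO[C@@](Cn6cnnn6)(c6ccc(Cl)cc6Cl)O5)cc4)CC3)cc2)c1=O` differs from it as follows: 1H-tetrazol-1-yl in place of 2,5-dimethyl-1H-imidazol-1-yl on a saturated chain carbon bound to a saturated ring carbon. In words, this is 1H-tetrazol-1-yl in place of 2,5-dimethyl-1H-imidazol-1-yl on a saturated chain carbon bound to a saturated ring carbon.

Among the measured compounds shown here, no measured step makes this exact swap. The nearest guides are a 3.5-fold higher number from compound 2 to compound 3 (0.54 log units; beyond the scatter) and a 2.2-fold higher number from compound 1 to compound 3 (0.34 log units; beyond the scatter), while a 1.6-fold lower number from compound 1 to compound 2 (0.20 log units; within the scatter). Both other groups give lower numbers than the one leaving, so a modest fall in this assay is expected, though with real uncertainty.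

The estimated step is a 2.2-fold lower number from compound 3 to compound 4 (0.34 log units; beyond the scatter). The estimate for compound 4 is 350 nM, within an expected range of 130 nM to 950 nM.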

Compound 4, half-maximal inhibitory concentration: 73 nM
Estimate against measurement, compound 4: 4.8-fold (0.68 log units) above; measured number outside the range, below it.
By their numbers in this assay, from the lowest: compound 4; then compounds 2 and 1 (each within the scatter of the next); then compound 3.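

In this assay the ring on this saturated chain carbon decides a great deal: 1H-tetrazol-1-yl gives a 10-fold lower number from compound 3 to compound 4 (1.02 log units; beyond the scatter) and a 3.0-fold lower number from compound 2 to compound 4 (0.48 log units; beyond the scatter) and also improves on the methyl end of the ethyl chain with a 4.8-fold lower number from compound 1 to compound 4 (0.68 log units; beyond the scatter) as its step. Among the compounds shown here, neither dimethylated ring had given a lower number than methyl beyond the scatter, so this is the first ring here to do so. Nothing shown explains the gain.

1H-tetrazol-1-yl differs from both other rings in having no methyl groups and in its nitrogen count, and these two changes remain unseparated. An unsubstituted 1H-1,2,4-triazol-1-yl or 1H-imidazol-1-yl at this place would pull them apart.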